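A macrocyclic lactam series: swapping the group on the amide carbonyl

A few compounds are considered here, and "the series" means these few. Any claim that something is new, unique, unknown or untested is made for them only; others in the source may bear on it.

Two members of a shared macrocyclic core have been tested in a functional assay on U-87MG ATCC cells (Homo sapiens) for antiproliferative activity; a lower number here means a stronger inhibitor, a higher number a weaker inhibitor. Compound 1, with structure `CC(=O)N1CCCc2c(C)c3c(n2-c2ccc(C(N)=O)c(c2)N[C@@H](C)[C@@H]1C)CC(C)(C)CC3=O`, gives 29 nM in this assay. Compound 2, with structure `Cc1c2c(n3c1CCN(C(=O)CN)C[C@@H](C)[C@H](C)Nc1cc-3ccc1C(N)=O)CC(C)(C)CC2=O`, carries an aminomethyl group on the ring amide carbonyl and gives 378 nM in this assay, the higher of the two numbers; the gap to compound 1 lies well beyond the usual scatter, and the two compounds differ in more than one place, so no single cause can be read from them.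

Compound 3, with structure `Cc1c2c(n3c1CCN(C(=O)[C@@H](O)C(C)C)C[C@@H](C)[C@H](C)Nc1cc-3ccc1C(N)=O)CC(C)(C)CC2=O`, differs from compound 2 in one place: 1-hydroxy-2-methylpropyl in place of aminomethyl on a carbonyl carbon. The aminomethyl group leaves and a 1-hydroxy-2-methylpropyl group enters on the same carbonyl carbon, whose other neighbour is the amide-type nitrogen in the ring. Nothing measured here shows how this assay answers to such a change, so the expectation is loosely held. The step from compound 2 to compound 3 is expected to be a modest lowering, a 2.5-fold lower number from compound 2 to compound 3 (0.40 log units; beyond the scatter), at about the edge of the scatter. Compound 3 is therefore estimated at 150 nM in this assay, with a likely range from 40 nM to 500 nM.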

Compound 3, half-maximal inhibitory concentration: 76 nM
Compound 3: middle estimate off by 2.0-fold (0.30 log units), on the high side, and the stated range covers the measured number.
By their numbers in this assay, from the lowest: compound 1; then compound 3; then compound 2.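

For the compounds shown here, compound 2 and compound 3 differ in one place only, which makes this the first readable step. In this assay, putting 1-hydroxy-2-methylpropyl in place of aminomethyl on the carbonyl carbon gives a 5.0-fold lower number from compound 2 to compound 3 (0.70 log units; beyond the scatter) and this lies beyond the scatter, so the number does answer to the group at this position, and a group of 5 heavy atoms in place of one of 2 comes with no loss of activity. Nothing available explains the step, and the swap changes several things at once: nitrogen leaves, oxygen enters, the chain grows and branches, and a defined stereocentre appears.

The compounds shown do not tell which of these changes goes with the lower number; a 1-amino-2-methylpropyl group on the same carbonyl carbon would keep the branched chain with nitrogen in place of oxygen, and a hydroxymethyl group would keep the oxygen without the branch. Going by these compounds, whether the opposite arrangement at the new stereocentre gives a similar number also stays open.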